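The compounds below may be only part of what the source reports. "The series", "measured", "known", "first", "only" and "open" are said of these compounds alone.

Measured so far:
compound 1 `CCCNC(=O)CC1CCc2cc(OC)c(OC)cc21` — 18.8%
compound 2 `CCCCCCNC(=O)CC1CCc2cc(OC)c(OC)cc21` — 47.6%
compound 3 `COc1cc2c(cc1OC)C(CC(=O)N1CCCC1)CC2` — 4.69%

All three share one core and differ only in the group on the carbonyl carbon. In a functional assay on the whole organism (strain Wistar) for inhibition, with Rattus norvegicus as the target, read by paw edema, with stated times of 60 min and 1 h, at a dose of 100 mg/kg by the oral route (on this read-out higher numbers stand for more inhibition at the one dose given (going by the name of the read-out) and lower numbers for less inhibition), compound 1 stands second highest of the three numbers: compound 3 lies nearest, with a number 14.1 percentage points lower from compound 1 to compound 3 (beyond the scatter), and compound 2 furthest, with a number 28.8 percentage points higher from compound 1 to compound 2 (beyond the scatter). The two open-chain amides thus sit above the one cyclic amide, and the longer chain of compound 2 sits above the shorter chain of compound 1.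

Compound 4 `COc1cc2c(cc1OC)C(CC(=O)N1CCNCC1)CC2` is not yet measured in this assay. Against compound 1 the change is piperazin-1-yl in place of propylamino on a carbonyl carbon. Among the measured compounds shown here, the steps that bear on it are those in which a cyclic group takes the place of an alkylamino group on the same carbonyl carbon: a number 14.1 percentage points lower from compound 1 to compound 3 (beyond the scatter) and a number 42.9 percentage points lower from compound 2 to compound 3 (beyond the scatter). Both lowered the read-out beyond the scatter. For the measured compounds named here, compound 4 carries a cyclic group of the same kind, so a lowering beyond the scatter from compound 1 is expected; the second ring nitrogen has no counterpart among the measured compounds, so its effect is not known from these data and the range is kept wide. The step expected is a number 10.8 percentage points lower from compound 1 to compound 4 (beyond the scatter). For compound 4 the estimate in this assay is 8%, between 0% and 25%.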

Compound 4, a percentage reported as inhibition, in the whole organism at one dose (the size of the read-out at that dose, not a potency): 62.5%
Compound 4: the middle estimate sits 54.5 percentage points below what was measured, outside the stated range (above it).
By their numbers in this assay, from the lowest: compound 3; then compound 1; then compound 2; then compound 4.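

In this assay, a ring on the carbonyl carbon does not by itself lower the read-out: piperazin-1-yl in place of propylamino gives a number 43.7 percentage points higher from compound 1 to compound 4 (beyond the scatter), and piperazin-1-yl in place of hexylamino gives a number 14.9 percentage points higher from compound 2 to compound 4 (beyond the scatter), so compound 3 alone now fits the earlier picture of a cyclic amide sitting low, and compound 4 goes against it. Among the compounds shown here, the choice of ring matters at this position, with piperazin-1-yl in place of pyrrolidin-1-yl giving a number 57.8 percentage points higher from compound 3 to compound 4 (beyond the scatter), a step larger than any seen among the earlier compounds. Nothing available explains why this change raises the read-out so far.

Compound 3 and compound 4 differ both in ring size and in the second ring nitrogen, so the compounds shown do not separate these two changes; a piperidin-1-yl group would keep the six-membered ring without that nitrogen, and a morpholin-4-yl group would put an oxygen in its place. A 4-methylpiperazin-1-yl group would test whether the hydrogen on the second ring nitrogen is needed for the higher read-out.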